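This account rests on a few compounds, and the source may have more. Where it says the series, first, only, none or still open, it means among the compounds named here.

Measured compounds in an assay on HEK293 cells for inhibition of transient receptor potential cation channel subfamily M member 8 (Homo sapiens), read by FLIPR, with stated times of 5 min and 3 min; a lower number here means a stronger inhibitor, a higher number a weaker inhibitor:

Compound 1 `CCOC(=O)c1cnc(-c2ccccc2)s1` gives > 100000 nM in this assay; that is a limit of the assay, not a number.
Compound 2 `CCOC(=O)c1oc(-c2ccc(Cl)cc2)nc1O` gives > 100000 nM; likewise a limit.
Compound 3 `COC(=O)c1nc(-c2ccccc2)sc1O` gives > 100000 nM; also a limit.

Compound 1 therefore stands at the limit of > 100000 nM in this assay, at which 3 of the 3 values shown sit. For the measured compounds named here, nothing measured on the series sits away from that limit, and no two measured compounds differ in only one place, so there is no measured step from which the size of a single structural change can be gauged. Compound 4 `CCOC(=O)c1sc(-c2ccccc2)nc1OC` has not yet been measured in this assay. It differs from compound 1 by methoxy in place of hydrogen on an aromatic carbon. With every measured compound returning only a limit, the data give no indication that a change of this kind moves the read-out in either direction. The expected step is a number no higher from compound 1 to compound 4 (the limit leaves the size open), in effect none beyond the usual scatter of the assay. For compound 4 the half-maximal inhibitory concentration is estimated at 100000 nM, with a range of 30000 nM to 300000 nM, and the most likely outcome is that this assay again reports only a limit rather than a number.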

Compound 4, half-maximal inhibitory concentration: > 100000 nM
Compound 4: a limit, no number; the forecaster's own chance of this, stated with the estimate: 75%; the middle value lies on the limit itself.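

Compound 1 and compound 4 both return only a limit, not a number, in this assay, so methoxy in place of hydrogen on an aromatic carbon gives no readable step: the limit of > 100000 nM in this assay, at which 4 of the 4 values shown sit.

The compounds shown leave open what size this change has and whether any compound of the series gives a measurable half-maximal inhibitory concentration.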